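A few compounds are considered here, and "the series" means these few. Any claim that something is new, unique, unknown or untested is made for them only; others in the source may bear on it.

Among the measured compounds shown here, compound 3 `O=[N+]([O-])c1ccc(Nc2nc(SCc3ccc(C(F)(F)F)cc3)nc3ccccc23)cc1` gives 8170 nM in a functional assay on MGC-803 cells (Homo sapiens) for cytotoxicity, read by MTT assay, with a stated time of 72 h (on this read-out higher numbers stand for weaker inhibition and lower numbers for stronger inhibition), the lowest of the three numbers measured so far. Its nearest neighbour is compound 1 `CCCCCCNc1nc(SCc2ccc(C(F)(F)F)cc2)nc2ccccc12`, which gives 13100 nM in this assay, a gap that stays within the scatter, so the two cannot be ranked against each other. Compound 2 `FC(F)(F)c1ccc(CSc2nc(N3CCCCC3)c3ccccc3n2)cc1` gives 18600 nM in this assay, and the step of a 2.3-fold lower number from compound 2 to compound 3 (0.36 log units; beyond the scatter) is the only one among the three that reaches beyond the scatter.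

Compound 4 `COc1ccc(Nc2nc(SCc3ccc(C(F)(F)F)cc3)nc3ccccc23)cc1OC` differs from compound 3 in one place: 3,4-dimethoxyphenyl in place of 4-nitrophenyl on a nitrogen on an aromatic ring. For the measured compounds named here, of the measured steps, only the step from compound 1 to compound 3 touches the substituent on that nitrogen, and it reads a 1.6-fold lower number from compound 1 to compound 3 (0.21 log units; within the scatter), a shift within the scatter. The steps of a 1.4-fold higher number from compound 1 to compound 2 (0.15 log units; within the scatter) and a 2.3-fold lower number from compound 2 to compound 3 (0.36 log units; beyond the scatter) alter the amino group itself rather than the aryl group on it, and so bear only loosely on the present change. Going by the values given here, no measured pair exchanges one aryl group on this nitrogen for another. On that basis the step of a 1.2-fold higher number from compound 3 to compound 4 (0.09 log units; within the scatter) is expected to be small, with no clear direction beyond the scatter. Compound 4 is therefore estimated at 10000 nM in this assay, with a range from 4000 nM to 25000 nM.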

Compound 4, half-maximal inhibitory concentration: 16300 nM
The estimate for compound 4 lay 1.6-fold (0.21 log units) below the measured number; the measured number falls inside the stated range.
By their numbers in this assay, from the lowest: compounds 3, 1, 4 and 2 (each within the scatter of the next, the first and the last beyond it).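

Among the compounds shown here, the new result is the first direct exchange of one aryl group for another on this nitrogen, and in this assay it reads a 2.0-fold higher number from compound 3 to compound 4 (0.30 log units; within the scatter) so 4-nitrophenyl and 3,4-dimethoxyphenyl cannot be told apart at this position. For the compounds shown here, the comparison with the hexylamino compound reads a 1.2-fold higher number from compound 1 to compound 4 (0.09 log units; within the scatter) and the comparison with the piperidin-1-yl compound reads a 1.1-fold lower number from compound 2 to compound 4 (0.06 log units; within the scatter) so the one earlier step beyond the scatter, from piperidin-1-yl to (4-nitrophenyl)amino, has no counterpart with (3,4-dimethoxyphenyl)amino, and an aryl group on this nitrogen does not by itself separate a compound from the piperidin-1-yl one. Nothing available here bears on the reason for these numbers.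

The compounds shown leave open whether an aryl group on this nitrogen carrying an amine or a carboxylic acid, or a chain longer than hexyl, would give a number beyond the scatter from those of compound 3 and compound 4. They also leave open whether a change elsewhere on the shared core, such as a nitrile in place of trifluoromethyl, would matter more than the group on this nitrogen.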